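Swapping a chloro for a phenyl on a shared core

The compounds below may be only part of what the source reports. "The series", "measured", "known", "first", "only" and "open" are said of these compounds alone.

Three compounds of one shared core have been examined in a functional assay on HEL cells (Homo sapiens) for cytotoxicity; a lower number here means that less compound is tolerated, a higher number that more compound is tolerated. Compound 1 `CO[C@@H]1[C@@H](OC)[C@H](c2ccccc2)O[C@@H]2CO[C@@H](c3ccccc3)O[C@@H]12` has "not determined" (no result reported) in this assay. Compound 2 `CO[C@@H]1[C@@H](OC)[C@H](c2ccccc2)O[C@@H]2CO[C@@H](c3ccc([N+](=O)[O-])cc3)O[C@@H]12` likewise has "not determined" (no result reported) in this assay. Compound 3 `CO[C@@H]1[C@@H](OC)[C@H](c2ccccc2)O[C@@H]2CO[C@@H](c3ccc(Cl)cc3)O[C@@H]12` is the only one with a reported result: in this assay compound 3 reaches >= 100 ug/mL, which is a limit of the assay rather than a measured number. This fits (the limit of >= 100 ug/mL in this assay, at which 1 of the 3 values shown sits), so compound 3 stands at the tolerated edge of what was tested, with no single value to compare against.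

Compound 4 `CO[C@@H]1[C@@H](OC)[C@H](c2ccccc2)O[C@@H]2CO[C@@H](c3ccc(-c4ccccc4)cc3)O[C@@H]12` is the next compound. It differs from compound 3 in one place: phenyl in place of chloro on an aromatic carbon. Among the measured compounds shown here, no step between two measured compounds is available to guide what such a change does in this assay, so the expectation rests on compound 3 alone, and a step no larger than the scatter is expected, as a number no higher from compound 3 to compound 4 (the limit leaves the size open) from compound 3 to compound 4 expresses. Compound 4 is therefore expected to give about 100 ug/mL in this assay, within a range from 50 ug/mL to 200 ug/mL.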

Compound 4, minimum cytotoxic concentration: >= 16 ug/mL
Compound 4: no number, only a limit; the forecaster's own chance of this, stated with the estimate: 70%; the middle value lies beyond the limit too.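

Among the compounds shown here, compound 3 and compound 4 each have only a limit rather than a number in this assay, so no step between them can be read. The compounds shown leave open whether phenyl in place of chloro changes how much compound is tolerated, and by how much.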